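The source may report more compounds than this note shows. Statements on the series, on what has been measured and on what is new or still open speak of the compounds shown alone.

Measured so far in an assay on isolated protein for inhibition of Voltage-dependent L-type calcium channel subunit alpha-1C (Cavia porcellus); a higher number here means a weaker inhibitor, a lower number a stronger inhibitor:

compound 1, `COC(=O)C1=C(C)NC(C)=C(C(=O)OC)C1c1[nH]cnc1Cl`, gives 1200 nM
compound 2, `COC(=O)C1=C(C)NC(C)=C(C(=O)OCc2ccccc2)C1c1[nH]cnc1Cl`, gives 93.3 nM
compound 3, `COC(=O)C1=C(C)NC(C)=C(C(=O)OCCc2ccccc2)C1c1[nH]cnc1Cl`, gives 79.4 nM

Compound 3 holds the lowest number of the three, but its gap to compound 2 is within the scatter, so the two cannot be ranked against each other; only compound 1 stands clearly apart.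

Three steps connect the measured compounds. The step of a 13-fold lower number from compound 1 to compound 2 (1.11 log units; beyond the scatter) and the step of a 15-fold lower number from compound 1 to compound 3 (1.18 log units; beyond the scatter) are both large, each from putting an aromatic group on a saturated chain carbon bound to an oxygen next to a carbonyl group. The step of a 1.2-fold lower number from compound 2 to compound 3 (0.07 log units; within the scatter) is within the scatter: exchanging benzyl for phenyl at that same place leaves the number essentially unchanged.

Compound 4, `CCOC(=O)C1=C(C)NC(C)=C(C(=O)OCCc2ccccc2)C1c1[nH]cnc1Cl`, differs from compound 3 by methyl in place of hydrogen on a saturated chain carbon bound to an oxygen next to a carbonyl group. Within the data shown here, no measured step alters this group directly. The nearest guide is the step from compound 2 to compound 3, where a one-carbon change at a chain carbon of this kind stayed within the scatter; the large steps involved an aromatic group, which this change does not. The expected step of a 1.1-fold lower number from compound 3 to compound 4 (0.05 log units; within the scatter) is therefore small, in either direction or none beyond the scatter. Compound 4 is estimated at 70 nM in this assay, with a range from 30 nM to 170 nM.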

Compound 4, half-maximal inhibitory concentration: 70.8 nM
The estimate for compound 4 lay 1.0-fold (0.00 log units) below the measured number; low and high end bracket the measured number.
By their numbers in this assay, from the lowest: compounds 4, 3 and 2 (each within the scatter of the next); then compound 1.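

In this assay, among these compounds, methyl in place of hydrogen on a saturated chain carbon bound to an oxygen next to a carbonyl group turns methoxycarbonyl into ethoxycarbonyl, and it gives a 1.1-fold lower number from compound 3 to compound 4 (0.05 log units; within the scatter) as the first reading of a change to this group, which compound 1, compound 2 and compound 3 all carry as methoxycarbonyl. This position therefore accepts one added carbon without a change beyond the scatter, at least with the rest of compound 3 held constant, whereas the large steps in the series came from the aromatic groups on the other ester. No measurement here bears on why this change leaves the number in place.

Going by these compounds, whether this position accepts more than one added carbon stays open: a longer chain such as propyl, a branched group such as isopropyl, or a benzyl group could behave differently from ethoxycarbonyl. On these data alone, it is also open whether the same methyl change would stay within the scatter with the rest of compound 1 or compound 2 in place of the rest of compound 3.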